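The compounds below may be only part of what the source reports. "The series", "measured", "known", "first", "only" and "open" are said of these compounds alone.

Measured in a functional assay on U-87MG ATCC cells (Homo sapiens) for antiproliferative activity; a higher number here means a weaker inhibitor, a lower number a stronger inhibitor:
- compound 1 `Cc1c2c(n3c1CCNC[C@@H](C)[C@H](C)Nc1cc-3ccc1C(N)=O)CC(C)(C)CC2=O`: 40 nM
- compound 2 `CC(=O)N1CCCc2c(C)c3c(n2-c2ccc(C(N)=O)c(c2)N[C@@H](C)[C@@H]1C)CC(C)(C)CC3=O`: 29 nM
- compound 3 `Cc1c2c(n3c1CCCN(C(=O)CN)[C@@H](C)[C@H](C)Nc1cc-3ccc1C(N)=O)CC(C)(C)CC2=O`: 481 nM

Compound 1 and compound 2 lie within the scatter of each other, while compound 3 has a clearly higher number than either. Compound 4 `CC[C@H](N)C(=O)N1CCc2c(C)c3c(n2-c2ccc(C(N)=O)c(c2)N[C@@H](C)[C@H](C)C1)CC(C)(C)CC3=O` is made from compound 1 by placing (1-aminopropyl)carbonyl in place of hydrogen on an amine nitrogen in a ring.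

Going by the values given here, one measured step bears on this change. It is a 17-fold higher number from compound 2 to compound 3 (1.22 log units; beyond the scatter), a large step, where amino replaced hydrogen on a saturated chain carbon bound to a carbonyl carbon. The entering group in compound 4 also has an amino group on such a carbon. However, compound 2 and compound 3 do not share the core of compound 1, and no acylated compound with that exact core has been measured. The precedent is therefore only a guide, and a sizeable rise in the number is expected, though perhaps less than the full step. The expected change is a 7.5-fold higher number from compound 1 to compound 4 (0.88 log units; beyond the scatter). For compound 4 the estimated value is 300 nM, with an expected range of 90 nM to 900 nM.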

Compound 4, half-maximal inhibitory concentration: 45 nM
The estimate for compound 4 lay 6.7-fold (0.82 log units) above the measured number; the measured number lies below the stated range.
By their numbers in this assay, from the lowest: compounds 2, 1 and 4 (each within the scatter of the next); then compound 3.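

Placing (1-aminopropyl)carbonyl on the amine nitrogen in the ring gives a 1.1-fold higher number from compound 1 to compound 4 (0.05 log units; within the scatter) in this assay, so on the core of compound 1 this position accepts an entering group of 6 heavy atoms without a change beyond the scatter. The earlier compounds shown here offered only a 17-fold higher number from compound 2 to compound 3 (1.22 log units; beyond the scatter), on a different core, so an amino group on the carbon bound to the carbonyl does not bring a large rise in every setting. No evidence is available to explain why these two steps differ.

Still open, on these data alone, is whether this position also accepts a carboxylic acid in place of the amino group, or a longer chain between the amino group and the carbonyl. The other stereo form of the 1-aminopropyl group also remains untested among these compounds.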